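A few compounds are considered here, and "the series" means these few. Any claim that something is new, unique, unknown or untested is made for them only; others in the source may bear on it.

Measured so far:
Compound 1 `CC(=O)Oc1ccc(-c2cncn2C2CCN(C(=O)c3ccc(Cl)c(C(F)(F)F)c3)CC2)cc1`: > 10000 nM
Compound 2 `O=C(c1ccc(Cl)c(C(F)(F)F)c1)N1CCC(n2cncc2-c2ccc(OS(=O)(=O)c3cccc(Br)c3)cc2)CC1`: 896 nM
Compound 3 `COc1ccc(C(=O)N2CCC(n3cncc3-c3ccc(OS(=O)(=O)c4cccc5cnccc45)cc3)CC2)cc1`: 77 nM

All three were tested in an assay on HEK293 cells for antagonist activity at P2X purinoceptor 7 (Homo sapiens), read by fluorescence, with a stated time of 2 h; on this read-out higher numbers stand for weaker inhibition and lower numbers for stronger inhibition. Compound 1 gives > 10000 nM, which is a limit of the assay and not a number (the limit of > 10000 nM in this assay, at which 1 of the 3 values shown sits). Compound 2 gives 896 nM, and compound 3 gives 77 nM, the lowest of the two numbers available, with compound 2 showing a clearly higher number. Among the compounds with values here, the only step measured in one place is an at least 11-fold lower number from compound 1 to compound 2 (1.04 log units; beyond the scatter), and it concerns the group on the oxygen of the aromatic ring, not the carbonyl side of the shared core.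

Compound 4 `CN(C)c1cccc(C(=O)N2CCC(n3cncc3-c3ccc(OS(=O)(=O)c4cccc5cnccc45)cc3)CC2)c1` is the next compound. It differs from compound 3 in one place: 3-(dimethylamino)phenyl in place of 4-methoxyphenyl on a carbonyl carbon. Within the data shown here, no measured step touches this part of the molecule, so there is nothing among the measured compounds that points to either a stronger or a weaker result. Without such guidance the expectation is a step of no size beyond the usual scatter, a 1.3-fold higher number from compound 3 to compound 4 (0.11 log units; within the scatter), in either direction. Compound 4 is therefore expected to give about 100 nM in this assay, within an estimated range of 30 nM to 350 nM.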

Compound 4, half-maximal inhibitory concentration: 155 nM
For compound 4 the middle estimate is 1.6-fold (0.19 log units) below the measured one; the measured number falls inside the stated range.
By their numbers in this assay, from the lowest: compounds 3 and 4 (each within the scatter of the next); then compound 2. At a limit, above all of these: compound 1.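

Within the data shown here, replacing the group on the carbonyl carbon, a part of the molecule that no earlier step touched, gives a 2.0-fold higher number from compound 3 to compound 4 (0.30 log units; within the scatter) in this assay. The 4-methoxyphenyl and 3-(dimethylamino)phenyl groups therefore cannot be told apart at this position, even though they carry different substituents on the same kind of aromatic ring. This single pair shows that at least one such exchange on the carbonyl carbon leaves the number within the scatter, but nothing measured here explains this result.

The compounds shown leave open whether this position would also accept a group with no aromatic ring, such as a cyclohexyl ring or a plain butyl chain, or a phenyl ring carrying a carboxylic acid or a primary amine. They also leave open whether 3-(dimethylamino)phenyl and 4-methoxyphenyl would still match each other if the sulfonyl group on the oxygen were a different one, such as the (3-bromophenyl)sulfonyl group of compound 2.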